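The source may report more compounds than this note shows. Statements on the series, on what has been measured and on what is new or still open speak of the compounds shown alone.

Measured compounds in an assay on isolated protein for inhibition of protein kinase C zeta type (Homo sapiens), with a stated time of 4 min; a higher number here means a weaker inhibitor, a lower number a stronger inhibitor:

compound 1, `CC(C)(C)C1=NN(c2ccc(F)cc2)C(c2ccc(O)cc2)C1`, 9400 nM
compound 2, `CC(C)(C)C1=NN(c2ccc(C(F)(F)F)cc2)C(c2ccc(O)cc2)C1`, 8800 nM
compound 3, `CC(C)(C)C1=NN(c2ccc(C(=O)O)cc2)C(c2ccc(O)cc2)C1`, "not determined" (no result reported)

Among the compounds with values here, compound 1 holds the highest of the two numbers in this assay, but its only neighbour with a number, compound 2, sits within the scatter: a 1.1-fold lower number from compound 1 to compound 2 (0.03 log units; within the scatter). Within the data shown here, compound 3 contributes no number, so the series so far shows a single pair with no spread beyond repeat variation.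

Compound 4, `CC(C)(C)C1=NN(c2cccc(Cl)c2)C(c2ccc(O)cc2)C1`, is not yet measured. Relative to compound 1 the change is 3-chlorophenyl in place of 4-fluorophenyl on an amine nitrogen in a ring.

Among the measured compounds shown here, the one measured step, from compound 1 to compound 2, also alters the aryl group on the ring nitrogen and is within the scatter; it does not, however, exchange a 4-fluorophenyl for a 3-chlorophenyl, so no measured step bears directly on the change in compound 4. For the measured compounds named here, with the only related step flat and no other guide, the expectation for compound 4 is no change beyond the scatter, in either direction: a 1.0-fold lower number from compound 1 to compound 4 (0.02 log units; within the scatter).

For compound 4 in this assay the estimate is therefore 9000 nM, with an expected range from 3000 nM to 27000 nM.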

Compound 4, half-maximal inhibitory concentration: 5200 nM
Beside the measured number, compound 4's estimate is 1.7-fold (0.24 log units) above it; the range from low to high includes it.
By their numbers in this assay, from the lowest: compounds 4, 2 and 1 (each within the scatter of the next).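

In this assay, the aryl group on the ring nitrogen has now been changed in both its halogen and the halogen's place, with 3-chlorophenyl in place of 4-fluorophenyl giving a 1.8-fold lower number from compound 1 to compound 4 (0.26 log units; within the scatter). The earlier readable step, a 1.1-fold lower number from compound 1 to compound 2 (0.03 log units; within the scatter), exchanged only the group on the phenyl ring, so compound 4 extends the flat picture at this position to a change that also moves the substituent, and the step stays within the scatter. No measurement shown here offers an explanation for this step.

Within the data shown here, the single step changes the halogen and its place together, so a 4-chlorophenyl or 3-fluorophenyl group would be needed to tell the two changes apart. On these data alone, it also remains open whether an aminophenyl or methoxyphenyl group on this nitrogen would give a step beyond the scatter, and whether replacing the tert-butyl group or the 4-hydroxyphenyl group of the shared core with, for example, a methyl group or a 4-methoxyphenyl group would do so.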